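Trifluoromethyl for methoxy on the aryl ring of compound 1

The compounds below may be only part of what the source reports. "The series", "measured", "known", "first", "only" and "open" are said of these compounds alone.

Compound 1 `COc1cccc(/C=C/C(=O)c2ccc(OC)c3c2OC(C)(C)C=C3)c1` in a functional assay on HepG2 cells (Homo sapiens) for antiproliferative activity, read by MTT assay, with a stated time of 24 h; on this read-out higher numbers stand for weaker inhibition and lower numbers for stronger inhibition: compound 1 gives > 10000 nM, a limit of the assay.
Compound 2 `COc1ccc(C(=O)/C=C/c2ccc(Br)cc2)c2c1C=CC(C)(C)O2` in this assay: compound 2 gives > 10000 nM, likewise a limit of the assay.

Among the compounds with values here, compound 1 thus stands only at a limit in this assay; no number is known for it, and the one further value is a limit as well. Within the data shown here, the single measured step, a step that the two limits leave unreadable from compound 1 to compound 2, cannot be read in size or direction, as both of its ends sit at the limit (the limit of > 10000 nM in this assay, at which 2 of the 2 values shown sit).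

Compound 3 `COc1ccc(C(=O)/C=C/c2cccc(C(F)(F)F)c2)c2c1C=CC(C)(C)O2` is compound 1 with trifluoromethyl in place of methoxy on an aromatic carbon. The change sits on the same aromatic ring that the step between compound 1 and compound 2 alters, but that step gives no readable size, so no direction beyond the scatter can be taken from the measured compounds. The expected step that the limit leaves unreadable from compound 1 to compound 3 therefore rests only on compound 1 showing nothing but a limit, > 10000 nM. Compound 3 is estimated at 15000 nM, within 4000 nM to 60000 nM, and most likely reported again only as a limit.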

Compound 3, half-maximal inhibitory concentration: > 10000 nM
Compound 3 gave a limit, no number (the forecaster's own chance of this, stated with the estimate: 75%); the middle value is on the limit's open side.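

No new step can be read: the pair of compound 1 and compound 3 has both ends only at a limit in this assay, not at a number: the limit of > 10000 nM in this assay, at which 3 of the 3 values shown sit.

The compounds shown leave open how far each lies beyond that limit in this assay, and whether trifluoromethyl in place of methoxy changes the activity at all.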